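This account rests on a few compounds, and the source may have more. Where it says the series, first, only, none or still open, it means among the compounds named here.

Compound 3, `C=C(Br)C(=O)Nc1cccc(-c2cn3c(-c4ccc(Cl)cc4)csc3n2)c1`, is the anchor for this step. In a functional assay on CCRF-CEM cells (Homo sapiens) for inhibition, read by cell counting, with a stated time of 3 days (a higher number here means a weaker inhibitor, a lower number a stronger inhibitor), compound 3 gives 2200 nM, the lowest of the three numbers in hand. Compound 1, `C=C(Br)C(=O)Nc1cccc(-c2cn3c(-c4ccccc4)csc3n2)c1`, gives 2800 nM in this assay, which sits within the scatter of compound 3, and the step of a 1.3-fold lower number from compound 1 to compound 3 (0.10 log units; within the scatter) is accordingly read as no real change. For the measured compounds named here, compound 2, `COc1ccc(-c2csc3nc(-c4cccc(N)c4)cn23)cc1`, gives 6100 nM, a gap from compound 3 that lies beyond the scatter; compound 2 differs from compound 3 in more than one place, so no single step is drawn from it.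

Compound 4, `C=C(Br)C(=O)Nc1cccc(-c2cn3c(-c4ccc(OC)cc4)csc3n2)c1`, differs from compound 3 by methoxy in place of chloro on an aromatic carbon. Going by the values given here, the only measured step that touches this position is the one from compound 1 to compound 3, which was within the scatter. Compound 2 carries a methoxy on the same ring, but alongside an amine rather than the bromoacrylamide, so its number speaks only for itself. With one flat step at this position and nothing else to lean on, no step beyond the scatter is expected in this assay for the exchange of chloro for methoxy. Compound 4 is therefore expected to give 3000 nM, with a range from 1200 nM to 7500 nM. For compound 4 this expectation amounts to a 1.4-fold higher number from compound 3 to compound 4 (0.13 log units; within the scatter).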

Compound 4, half-maximal inhibitory concentration: 500 nM
Estimate against measurement, compound 4: 6.0-fold (0.78 log units) above; measured number below the stated range.
By their numbers in this assay, from the lowest: compound 4; then compounds 3 and 1 (each within the scatter of the next); then compound 2.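

In this assay the position on the aryl ring is not flat after all: the change from 4-chlorophenyl to 4-methoxyphenyl gives (a 4.4-fold lower number from compound 3 to compound 4 (0.64 log units; beyond the scatter)), and methoxy in place of hydrogen gives (a 5.6-fold lower number from compound 1 to compound 4 (0.75 log units; beyond the scatter)), whereas chloro in place of hydrogen stayed within the scatter (a 1.3-fold lower number from compound 1 to compound 3 (0.10 log units; within the scatter)). For the compounds shown here, the response at this position therefore depends on which group sits there, and the single step with chloro did not speak for methoxy. Going by these compounds alone, with methoxy held constant, (1-bromoethenyl)carbonyl in place of hydrogen on the nitrogen gives the largest step in the set (a 12-fold lower number from compound 2 to compound 4 (1.09 log units; beyond the scatter)), the first single-place reading of that group, which the earlier compounds could not give. No measurement at hand accounts for either step.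

Still open, on these data alone, is whether the lower number belongs to methoxy alone or also extends to ethoxy, hydroxy or dimethylamino at the same position. Also open, as far as these compounds go, is how much of the step on the nitrogen depends on the bromine, which a plain acryloyl or an acetyl group on that nitrogen would address.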